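A few compounds are considered here, and "the series" means these few. Any claim that something is new, unique, unknown or untested is made for them only; others in the source may bear on it.

Measured in a functional assay on MGC-803 cells (Homo sapiens) for inhibition, read by CCK-8 assay, with a stated time of 48 h; a higher number here means a weaker inhibitor, a lower number a stronger inhibitor:
- compound 1 `COc1ccc(CN(C(=O)CSC(=S)N2CCN(C)CC2)c2cc(OC)c(OC)c(OC)c2)cc1`: 1280 nM
- compound 2 `COc1ccc(CN(C(=O)CSC(=S)N2CCOCC2)c2cc(OC)c(OC)c(OC)c2)cc1`: 2370 nM
- compound 3 `COc1ccc(CN(C(=O)CSC(=S)N2CCc3ccccc32)c2cc(OC)c(OC)c(OC)c2)cc1`: 8410 nM

Compound 3 has the highest number of the three, at 8410 nM, making it the weakest inhibitor so far. Compound 4 `COc1ccc(CN(C(=O)CSC(=S)N2CCc3cc(Br)ccc32)c2cc(OC)c(OC)c(OC)c2)cc1` keeps the same framework but carries bromo in place of hydrogen on an aromatic carbon, turning 2,3-dihydro-1H-indol-1-yl into 5-bromo-2,3-dihydro-1H-indol-1-yl: bromo in place of hydrogen on an aromatic carbon.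

The nearest evidence comes from changes to the group on the thiocarbonyl carbon. These gave a 3.5-fold higher number from compound 2 to compound 3 (0.55 log units; beyond the scatter) and a 6.6-fold higher number from compound 1 to compound 3 (0.82 log units; beyond the scatter), both modest, while a 1.9-fold higher number from compound 1 to compound 2 (0.27 log units; within the scatter) stayed within the scatter. None of these steps adds a bromo or any other group to the 2,3-dihydro-1H-indol-1-yl ring, so the data give no direction for this change. A modest step either way remains possible, but the central expectation is little change. The expected step is a 1.2-fold lower number from compound 3 to compound 4 (0.08 log units; within the scatter). For compound 4 the estimated value is 7000 nM, with an expected range from 2500 nM to 18000 nM.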

Compound 4, half-maximal inhibitory concentration: > 20000 nM
Compound 4 was reported as a limit; the forecaster's own chance of this, stated with the estimate: 5%; middle value at least 2.8-fold (0.45 log units) from the limit.
By their numbers in this assay, from the lowest: compounds 1 and 2 (each within the scatter of the next); then compound 3. At a limit, above all of these: compound 4.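

Compound 4 is reported only as a limit in this assay: the limit of > 20000 nM in this assay, at which 1 of the 4 values shown sits. Within the data shown here, this is the first change on the 2,3-dihydro-1H-indol-1-yl ring itself, and bromo in place of hydrogen on this aromatic carbon gives an at least 2.3-fold higher number from compound 3 to compound 4 (0.37 log units; beyond the scatter), so this position is not indifferent to substitution. Measured against the other groups on the thiocarbonyl carbon, 5-bromo-2,3-dihydro-1H-indol-1-yl gives an at least 8.4-fold higher number from compound 2 to compound 4 (0.92 log units; beyond the scatter) and an at least 15-fold higher number from compound 1 to compound 4 (1.19 log units; beyond the scatter), which places it further from morpholin-4-yl and 4-methylpiperazin-1-yl than the unsubstituted ring.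

The compounds shown leave open whether fluoro, methoxy or an amine on this same carbon would shift the number in the same direction. They also leave open whether bromo on another carbon of this ring would give a similar step.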